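A few compounds are considered here, and "the series" means these few. Any claim that something is new, unique, unknown or untested is made for them only; others in the source may bear on it.

Measured compounds:
compound 1 `CCOC(=O)c1cc(=O)c2cc(CSC(=S)N(C(C)C)C(C)C)ccc2o1`, in a functional assay on LM7 cells (Homo sapiens) for antiproliferative activity, read by MTT assay, with a stated time of 72 h; on this read-out lower numbers stand for stronger inhibition and higher numbers for weaker inhibition: > 25000 nM
compound 2 `Cc1ccc2c(=O)c(CSC(=S)N3CCCC3)coc2c1`, in this assay: 3400 nM

Compound 1 gives only a limit in this assay, (the limit of > 25000 nM in this assay, at which 1 of the 2 values shown sits), so no number is known for it; it stands at the weak end of what was seen. Compound 2, on a different core, gives 3400 nM in this assay, a measured number.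

The next compound, compound 3 `CCOC(=O)c1cc(=O)c2cc(CSC(=S)N3CCOCC3)ccc2o1`, is compound 1 with morpholin-4-yl in place of diisopropylamino on a thiocarbonyl carbon. For the measured compounds named here, no measured pair shows what this exchange does in this assay, so the size of the step is open.

Compound 3 is expected to reach roughly 15000 nM in this assay, within 3000 nM to 50000 nM. That expectation means a step from compound 1 to compound 3 of an at least 1.6-fold lower number from compound 1 to compound 3 (0.22 log units; that floor lies within the scatter), drawn from the limit of compound 1 and the measured number of compound 2; a second limit for compound 3 is a real possibility.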

Compound 3, half-maximal inhibitory concentration: > 25000 nM
Compound 3: a limit, no number (the forecaster's own chance of this, stated with the estimate: 45%); middle value at least 1.6-fold (0.22 log units) away from the limit.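

Compound 1 and compound 3 both give only a limit in this assay, not a number, so no step can be read for morpholin-4-yl in place of diisopropylamino: the limit of > 25000 nM in this assay, at which 2 of the 3 values shown sit.

The compounds shown leave open whether this exchange changes activity on the shared core at all.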